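The source may hold more compounds than are shown below. What is called first, only, known or untested is meant among the compounds shown, and "the series" means these compounds.

Two compounds of the series have been run in a functional assay on the whole organism (strain albino) for inhibition, with Rattus norvegicus as the target, read by paw edema, with stated times of 30 min and 5 h, at a dose of 0.28 mmol/kg by the oral route; on this read-out higher numbers stand for more inhibition at the one dose given (going by the name of the read-out) and lower numbers for less inhibition. Compound 1 `CCn1c(SCC(=O)Nc2ccc(/C(C)=N/O)cc2)nnc1-c1cc(OC)c(OC)c(OC)c1` gives 61% in this assay. Compound 2 `CCn1c(SCC(=O)Nc2ccc(C(C)=O)cc2)nnc1-c1ccc(OC)c(OC)c1` gives 66% in this assay. Compound 2 is the point of reference for the next compound; its number and that of compound 1 lie within the usual scatter of each other, so the two measured compounds stand together rather than apart. Among the compounds with values here, no step between them is defined, as they differ in more than one place.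

Compound 3 `CCn1c(SCC(=O)Nc2ccc(C(C)=O)cc2)nnc1-c1cc(OC)c(OC)c(OC)c1` has not been measured in this assay. Relative to compound 2 the change is methoxy in place of hydrogen on an aromatic carbon. Compound 3 thus carries the methoxy arrangement of compound 1 on the otherwise unchanged framework of compound 2. Nothing in the measured pair isolates this change from the other difference between compound 1 and compound 2, and neither measured compound stands apart from the other. The expected step from compound 2 to compound 3 in this assay is therefore small, a number 3 percentage points lower from compound 2 to compound 3 (within the scatter), with no direction beyond the scatter. Compound 3 is estimated at 63%, with a range from 48% to 78%.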

Compound 3, a percentage reported as inhibition, in the whole organism at one dose (the size of the read-out at that dose, not a potency): 64%
Compound 3: middle estimate off by 1 percentage points, on the low side; the range from low to high includes it.
By their numbers in this assay, from the lowest: compounds 1, 3 and 2 (each within the scatter of the next).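

In this assay, methoxy in place of hydrogen on the aromatic carbon ortho to a methoxy group gives a number 2 percentage points lower from compound 2 to compound 3 (within the scatter), so this position takes the added methoxy group without a step beyond the scatter. The two differences between compound 1 and compound 2 can now be read apart: with the methoxy arrangement held constant, a group of 3 heavy atoms in place of a group of 4 heavy atoms on the other aromatic ring gives a number 3 percentage points higher from compound 1 to compound 3 (within the scatter), and this change also stays within the scatter. No measurement shown here speaks to the reason for either step.

The compounds shown test this position only with hydrogen and methoxy, so it remains open whether an amine, a hydroxyl group or a longer chain such as butoxy there would move the number in this assay beyond the scatter. On the other aromatic ring, only the two groups in compound 1 and compound 3 are compared, leaving open what a carboxylic acid or an amide in that place would do.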